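The compounds below may be only part of what the source reports. "The series", "measured", "known", "first", "only" and "open" are said of these compounds alone.

Two compounds of the series have a number in a functional assay on A549 cells (Homo sapiens) for antiproliferative activity, read by MTT assay, with a stated time of 48 h; on this read-out lower numbers stand for stronger inhibition and higher numbers for weaker inhibition. Compound 1 `O=C(/C=C/c1ccc(Br)cc1)Nc1ccc2ncnc(Nc3cccc(Cl)c3)c2c1` gives 1.86 ug/mL in this assay. Among the compounds with values here, compound 2 `COc1cccc(/C=C/C(=O)Nc2ccc3ncnc(Nc4cccc(Cl)c4)c3c2)c1` gives 2.58 ug/mL, which stands as the higher of the two numbers, with compound 1 as its only neighbour and the gap to it within the scatter. Within the data shown here, the single step measured so far, a 1.4-fold higher number from compound 1 to compound 2 (0.14 log units; within the scatter), exchanges the group on the double-bonded chain carbon and remains within the scatter.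

Compound 3 `O=C(/C=C/c1ccc([N+](=O)[O-])cc1)Nc1ccc2ncnc(Nc3cccc(Cl)c3)c2c1` is not yet measured in this assay. It differs from compound 2 in one place: 4-nitrophenyl in place of 3-methoxyphenyl on a double-bonded chain carbon bound to a double-bonded chain carbon. Among the measured compounds shown here, only the step from compound 1 to compound 2 bears on this change, as it alters the same group at the same place, and that step was small. Nothing in the set separates one group at this place from another beyond the scatter, so for compound 3 no step beyond the scatter is expected in this assay. The estimate for compound 3 is 2 ug/mL, with a range from 0.9 ug/mL to 5 ug/mL. For compound 3 the expected step is a 1.3-fold lower number from compound 2 to compound 3 (0.11 log units; within the scatter).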

Compound 3, half-maximal inhibitory concentration: 5.26 ug/mL
The estimate for compound 3 lay 2.6-fold (0.42 log units) below the measured number, outside the stated range (above it).
By their numbers in this assay, from the lowest: compounds 1 and 2 (each within the scatter of the next); then compound 3.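

In this assay, within the data shown here, the group on this double-bonded chain carbon now proves able to move the number beyond the scatter: 4-nitrophenyl in place of 3-methoxyphenyl brings a 2.0-fold higher number from compound 2 to compound 3 (0.31 log units; beyond the scatter) and nitro in place of bromo on an aromatic carbon brings a 2.8-fold higher number from compound 1 to compound 3 (0.45 log units; beyond the scatter) as the first such steps. Compound 1 and compound 2 remain within the scatter of each other, while compound 3 stands apart from both on the side of weaker inhibition. Nothing measured on these compounds accounts for either step.

Going by these compounds, it remains open whether the higher number is particular to the nitro group or would also follow an amine or a carboxylic acid on the same aromatic carbon. A 4-methoxyphenyl group would show whether the methoxy group of compound 2 behaves like the bromo group of compound 1 on that same carbon.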